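Bromo for chloro on the methoxy-bearing core of compound 1

A few compounds are considered here, and "the series" means these few. Any claim that something is new, unique, unknown or untested is made for them only; others in the source may bear on it.

compound 1 `COc1ccc2[nH]c(=O)c(-c3nc4cc(Cl)ccc4[nH]3)cc2c1` — > 100000 nM
compound 2 `Cc1ccc2[nH]c(=O)c(-c3nc4cc(Cl)ccc4[nH]3)cc2c1` — 39000 nM
compound 3 `O=c1[nH]c2ccccc2cc1-c1nc2cc(Cl)ccc2[nH]1` — 16500 nM

In a functional assay on BEL-7404 cells for cytotoxicity against BEL-7404 tumor cell line (Homo sapiens), read by MTT assay, with a stated time of 48 h (a lower number here means a stronger inhibitor, a higher number a weaker inhibitor), compound 1 stands at a limit of the assay, > 100000 nM, not at a number; only this bound is known for it. Compound 2 gives 39000 nM and compound 3 gives 16500 nM. The measured steps all concern the methoxy position: an at least 2.5-fold lower number from compound 1 to compound 2 (0.40 log units; beyond the scatter), an at least 6.0-fold lower number from compound 1 to compound 3 (0.78 log units; beyond the scatter) and a 2.4-fold lower number from compound 2 to compound 3 (0.37 log units; beyond the scatter). Compound 4 `COc1ccc2[nH]c(=O)c(-c3nc4cc(Br)ccc4[nH]3)cc2c1` differs from compound 1 by bromo in place of chloro on an aromatic carbon. Within the data shown here, no measured step touches the chloro, so none bears directly on this change, and no step beyond the scatter is expected in either direction. Compound 4 is therefore estimated at 120000 nM, between 40000 nM and 400000 nM, which is the expected step that the limit leaves unreadable from compound 1 to compound 4, most likely reported again only as a limit.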

Compound 4, half-maximal inhibitory concentration: > 100000 nM
Compound 4: a limit, no number; the forecaster's own chance of this, stated with the estimate: 70%; the middle value does not contradict the limit.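

Compound 1 and compound 4 both sit at a limit, so no step from chloro to bromo can be read between them: the limit of > 100000 nM in this assay, at which 2 of the 4 values shown sit.

The compounds shown leave open whether bromo and chloro differ at all on the shared core.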